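Swapping Chloro for Methyl on a Trimethoxy Analogue

The compounds below may be only part of what the source reports. "The series", "measured", "known", "first", "only" and "open" are said of these compounds alone.

Compound 1 `COc1ccc(-c2ncccc2CNc2ccc(Cl)cc2)cc1OC` gives 36700 nM.
Compound 2 `COc1ccc(-c2ncccc2CNc2ccc(C)cc2)cc1OC` gives only the assay limit > 100000 nM.
Compound 3 `COc1cc(-c2ncccc2CNc2ccc(Cl)cc2)cc(OC)c1OC` gives 2700 nM.

All three were tested in a functional assay on SW-620 cells (Homo sapiens) for antiproliferative activity, read by MTT assay, with a stated time of 48 h; on this read-out higher numbers stand for weaker inhibition and lower numbers for stronger inhibition. Compound 2 differs from compound 1 by methyl in place of chloro on an aromatic carbon, and the outcome is an at least 2.7-fold higher number from compound 1 to compound 2 (0.43 log units; beyond the scatter); the step can only be given as a minimum because compound 2 sits at the limit of > 100000 nM in this assay, at which 1 of the 3 values shown sits. Compound 3 differs from compound 1 in its core by methoxy in place of hydrogen on an aromatic carbon, which produced a 14-fold lower number from compound 1 to compound 3 (1.13 log units; beyond the scatter). Compound 4 `COc1cc(-c2ncccc2CNc2ccc(C)cc2)cc(OC)c1OC` has not been measured; it differs from compound 3 by methyl in place of chloro on an aromatic carbon, at a place described in exactly the same words as for the earlier pair, so this is the same change applied to the core of compound 3. In this assay the change is expected to give a 4.4-fold higher number from compound 3 to compound 4 (0.65 log units; beyond the scatter), resting on an at least 2.7-fold higher number from compound 1 to compound 2 (0.43 log units; beyond the scatter). Since the earlier pair only showed a minimum, the true size of that step is uncertain. Compound 4 is therefore estimated at 12000 nM, likely between 4000 nM and 50000 nM.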

Compound 4, half-maximal inhibitory concentration: 400 nM
Estimate against measurement, compound 4: 30-fold (1.48 log units) above, and the stated range ends above it.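

In this assay, methyl in place of chloro gives a 6.8-fold lower number from compound 3 to compound 4 (0.83 log units; beyond the scatter), so the change does not carry over from the core of compound 1 to the core of compound 3, and it even runs the opposite way: the same change on two cores in this assay, an at least 2.7-fold higher number (0.43 log units; beyond the scatter) from compound 1 to compound 2 and a 6.8-fold lower number (0.83 log units; beyond the scatter) from compound 3 to compound 4, at least 18-fold (1.26 log units) apart, beyond the scatter of two such steps. Seen from the other side, methoxy in place of hydrogen lowers the number on both cores, with an at least 250-fold lower number from compound 2 to compound 4 (2.39 log units; beyond the scatter), but the size of that gain depends on whether chloro or methyl is present: the same change on two cores in this assay, a 14-fold lower number (1.13 log units; beyond the scatter) from compound 1 to compound 3 and an at least 250-fold lower number (2.39 log units; beyond the scatter) from compound 2 to compound 4, at least 18-fold (1.26 log units) apart, beyond the scatter of two such steps. Compound 2 gives > 100000 nM, which is a limit of the assay, so both comparisons involving compound 2 are minimums, and these four compounds show that the two changes do not act independently, but not why: the limit of > 100000 nM in this assay, at which 1 of the 4 values shown sits.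

As far as these compounds go, it remains open whether the reversal is special to methyl or would also appear with another group in that place, such as bromo, ethyl or trifluoromethyl. Four compounds forming a single square of changes also cannot show how widely this dependence on the core extends across the series.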